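The source may hold more compounds than are shown below. What is called first, only, known or untested is meant among the compounds shown, and "the series" means these compounds.

Compound 2 `C[C@H](Nc1nc(N)nc(N)c1C#N)c1c(-c2ccccc2)c(=O)n2cc(F)ccc2c1C1CC1` was tested in an ADME assay on microsomes from liver (Rattus norvegicus), read by LC-MS, using NADPH, with a stated time of 30 min, tested at 1 uM (on this read-out lower numbers stand for a less stable compound and higher numbers for a more stable compound), and gave 84%. Its closest relative among the measured compounds is compound 1 `Cc1c([C@H](C)Nc2nc(N)nc(N)c2C#N)c(-c2ccccc2)c(=O)n2cc(F)ccc12`, which in this assay gave 85%. For the measured compounds named here, these two numbers sit within the usual scatter of each other: the only measured step, a number 1 percentage points lower from compound 1 to compound 2 (within the scatter), counts as no change.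

Compound 3 `C[C@H](Nc1nc(N)nc(N)c1C#N)c1c(-c2ccccc2)c(=O)n2cc(F)ccc2c1-c1ccccc1` is the next compound. It differs from compound 2 in one place: phenyl in place of cyclopropyl on an aromatic carbon. This is the same position on the shared core that changed between compound 1 and compound 2, where a methyl gave way to a cyclopropyl. Going by the values given here, that change left the read-out untouched, and it is the only step that bears on the new one. With nothing else to go on, the expectation is that exchanging the cyclopropyl for a phenyl at this position also leaves the read-out within the scatter, and the estimated step is a number 4 percentage points lower from compound 2 to compound 3 (within the scatter).

For compound 3 the estimate in this assay is therefore 80%, with an expected range from 60% to 92%.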

Compound 3, percent of the compound remaining: 73%
Compound 3: middle estimate off by 7 percentage points, on the high side; the measured number falls inside the stated range.
By their numbers in this assay, from the lowest: compound 3; then compounds 2 and 1 (each within the scatter of the next).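

This position on the shared core is not indifferent in this assay. Methyl and cyclopropyl stood within the scatter of each other, but phenyl on this aromatic carbon gives a modest step beyond it, seen both as a number 11 percentage points lower from compound 2 to compound 3 (beyond the scatter) and as a number 12 percentage points lower from compound 1 to compound 3 (beyond the scatter), so a lower number here means less of the compound remains and compound 3 is the least stable of the three. No measurement shown here explains this difference, so the data record only that it occurs, not what lies behind it.

The three compounds leave open whether the loss of stability follows from the six-membered aromatic ring itself or from the higher count of heavy atoms, a question that a cyclohexyl group or a longer alkyl chain at this position could help to separate. They also leave open whether a phenyl ring carrying a substituent such as a fluorine or a nitrile, or a pyridine ring in its place, would give a number closer to that of compound 3 or to that of compound 2.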